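The source may hold more compounds than are shown below. What is called first, only, known or untested is meant among the compounds shown, and "the series" means these compounds.

Working notes on the isatin series, cytotoxicity arm. The shared core carries a triazolylmethyl arm whose distal amide is the only point varied here. Compound 1 `O=C(Cn1cc(CN2C(=O)C(=O)c3c(Cl)ccc(Cl)c32)nn1)NC1CCCCC1` bears a cyclohexylamide on that arm; in a toxicity assay on GES1 cells (Homo sapiens) for inhibition, read by CCK-8 assay, with a stated time of 72 h (a lower number here means a stronger inhibitor, a higher number a weaker inhibitor), compound 1 gives 47400 nM, a weak response against this non-malignant line. Among the measured compounds shown here, compound 2 `O=C1C(=O)N(Cc2cn(CC(=O)N3CCNCC3)nn2)c2c(Cl)ccc(Cl)c21` carries a piperazinylcarbonyl on the same arm; in this assay compound 2 gives "nd(insoluble)" (no result reported), which is no number at all, so compound 2 stands without a value here and no step from compound 1 can be drawn. Compound 3 `O=C1C(=O)N(Cc2cn(CC(=O)N3CCCC3)nn2)c2c(Cl)ccc(Cl)c21` is the next point: the change is pyrrolidin-1-yl in place of piperazin-1-yl on a carbonyl carbon. For the measured compounds named here, with no measured step anywhere in the set, the only anchor is compound 1, and a weak response of similar magnitude is expected for compound 3, with no direction beyond the scatter claimed. The estimate for compound 3 in this assay is 45000 nM, in the range 15000 nM to 120000 nM.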

Compound 3, half-maximal inhibitory concentration: 88700 nM
Beside the measured number, compound 3's estimate is 2.0-fold (0.29 log units) below it; the range from low to high includes it.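

In this assay the distal amide now has its first readable step, a 1.9-fold higher number from compound 1 to compound 3 (0.27 log units; within the scatter), so pyrrolidin-1-yl in place of cyclohexylamino on a carbonyl carbon separates compound 1 and compound 3 by no more than the usual scatter. The step from compound 2 to compound 3 cannot be read, since compound 2 has no number, and the piperazin-1-yl amide therefore gives no comparison at this position. Nothing at hand bears on the cause of this result.

Still open, going by these compounds, is whether morpholin-4-yl or dimethylamino on the same carbonyl carbon would stay within the scatter of compound 1 and compound 3. Also open, on these data alone, is how a carboxylic acid in place of the amide would read out in this assay series.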